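Compound 3: 4-nitrophenyl in place of 3-nitrophenyl

This account rests on a few compounds, and the source may have more. Where it says the series, first, only, none or still open, it means among the compounds named here.

Of the compounds shown here, two with a shared core have so far been read in an ADME assay on HeLa cells (Homo sapiens) for inhibition, read by MTT assay, with a stated time of 72 h (on this read-out higher numbers stand for weaker inhibition of growth and lower numbers for stronger inhibition of growth), and neither has yielded an exact number. Compound 1 (`O=C1CSc2ccccc2N1Cc1cn(-c2cccc([N+](=O)[O-])c2)nn1`) gives > 30 ug/mL as its result, which is a limit of the assay. Compound 2 (`O=C1CSc2ccccc2N1Cc1cn(Cc2cccc([N+](=O)[O-])c2)nn1`) gives > 30 ug/mL as its result, which is also a limit and not a number. Compound 2 therefore has no exact place on the scale, and the only other result shown is a limit too (the limit of > 30 ug/mL in this assay, at which 2 of the 2 values shown sit).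

Compound 3 (`O=C1CSc2ccccc2N1Cc1cn(Cc2ccc([N+](=O)[O-])cc2)nn1`) has yet to be measured. It carries 4-nitrophenyl in place of 3-nitrophenyl on a saturated chain carbon bound to an aromatic nitrogen. Among the compounds with values here, no measured step is available to scale this change, so the expectation rests on compound 2 and its limit (> 30 ug/mL). The expected step (a step that the limit leaves unreadable from compound 2 to compound 3) stays within the usual scatter in this assay and has no clear direction. Another limit is the likeliest report. For compound 3 the estimated value is 40 ug/mL within an expected range (18 ug/mL to 90 ug/mL).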

Compound 3, concentration for 50% growth inhibition in the HeLa assay: > 30 ug/mL
Compound 3: only a limit was reported; the forecaster's own chance of this, stated with the estimate: 75%; the middle value does not contradict the limit.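

In the HeLa assay compound 3 gives > 30 ug/mL. This result is a limit of the assay and not a number. Compound 2 also stands at a limit, so no step can be read from compound 2 to compound 3: the limit of > 30 ug/mL in the HeLa assay, at which 3 of the 3 values shown sit.

In a physicochemical assay, read by spectrophotometry (a higher number here means a weaker inhibitor, a lower number a stronger inhibitor), compound 2 gives 34.1 ug/mL, and compound 3 gives 27.4 ug/mL. In the physicochemical assay these two values amount to a 1.2-fold lower number from compound 2 to compound 3 (0.10 log units; within the scatter).

The compounds shown leave open where any of them would fall on the scale of the HeLa assay, and so whether 4-nitrophenyl and 3-nitrophenyl differ there at all.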